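Bromine Added to the Ketone Ring of Compound 1

The source may report more compounds than this note shows. Statements on the series, on what has been measured and on what is new or still open speak of the compounds shown alone.

The account follows three chalcones measured in a functional assay on MCF7 cells (Homo sapiens) for antiproliferative activity, read by sulforhodamine B assay, with a stated time of 72 h, tested at 10 uM (a higher number here means a weaker effect of the compound at the concentration tested, a lower number a stronger effect), and a fourth that awaits measurement. Compound 1 `COc1cc(Br)cc(/C=C/C(=O)c2ccccc2)c1O` gives 67% in this assay, the lowest of the three numbers. Compound 2 `O=C(/C=C/c1cc(F)cc(F)c1O)c1ccccc1` gives 110% in this assay, and compound 3 `COc1ccc(O)c(/C=C/C(=O)c2ccc(Cl)cc2)c1` gives 86.9% in this assay; both stand beyond the scatter above compound 1, so among the three compound 1 shows the strongest effect.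

Compound 4 `COc1cc(Br)cc(/C=C/C(=O)c2ccc(Br)cc2)c1O` differs from compound 1 in one place: bromo in place of hydrogen on an aromatic carbon. Going by the values given here, no pair among the measured compounds differs in exactly this way, so the data offer no direct measure of what the bromo brings. The values of compound 1 and compound 3 show that a halogen on the ketone-side ring does not by itself secure a low number, but those two compounds differ elsewhere as well.

The step of a number 2 percentage points lower from compound 1 to compound 4 (within the scatter) is expected to lie within the scatter. Compound 4 is estimated to give 65% in this assay, in a range from 45% to 88%.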

Compound 4, a percentage reported as activity, at one concentration (the size of the read-out at that concentration, not a potency): 64.6%
Estimate against measurement, compound 4: 0.4 percentage points above; measured number inside the range.
By their numbers in this assay, from the lowest: compounds 4 and 1 (each within the scatter of the next); then compound 3; then compound 2.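

Going by these compounds alone, the change from phenyl to 4-bromophenyl gives the first direct reading at this position: in this assay it amounts to a number 2.4 percentage points lower from compound 1 to compound 4 (within the scatter). Bromo on this aromatic carbon, para to a large group, is therefore accommodated with the number held where it stood, and no gain or loss can be told apart from the scatter. Nothing among the available data explains this outcome.

From the compounds shown here alone, what remains open is whether a different group at this position, such as an amine, a carboxylic acid or a longer alkyl chain, would move the number beyond the scatter. The compounds shown also leave open whether the same bromo would give a similar step on the core of compound 2.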